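Triazolylmethyl Spirooxindoles: Swapping the Aryl Group on the Triazole

The compounds below may be only part of what the source reports. "The series", "measured", "known", "first", "only" and "open" are said of these compounds alone.

Measured so far:
- Compound 1, `Cc1ccc(-n2nncc2CN2C(=O)C3(C(C#N)=C(N)Oc4c3c3nc5ccccc5nc3c3ccccc43)c3ccccc32)c(C)c1`, a limit only: in an ADME assay on L02 cells (Homo sapiens) for antiproliferative activity, read by MTT assay, with a stated time of 48 h (on this read-out higher numbers stand for weaker inhibition and lower numbers for stronger inhibition), compound 1 gives > 50000 nM.
- Compound 2, `N#CC1=C(N)Oc2c(N)cc3nc4ccccc4nc3c2C12C(=O)N(Cc1cnnn1-c1ccccc1Cl)c1ccccc12`, a limit only: in this assay compound 2 gives > 50000 nM.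

Neither value is a true number; each is the edge of what this assay can report. Compound 2 therefore sits at the same limit as compound 1, as the limit of > 50000 nM in this assay, at which 2 of the 2 values shown sit, shows, and nothing in the numbers separates the two.

Compound 3, `N#CC1=C(N)Oc2c(N)cc3nc4ccccc4nc3c2C12C(=O)N(Cc1cnnn1-c1c(F)cccc1F)c1ccccc12`, has not yet been tested. It differs from compound 2 in one place: 2,6-difluorophenyl in place of 2-chlorophenyl on an aromatic nitrogen. Because compound 2 reaches only the limit > 50000 nM, no measured step is available from which to gauge this change, and no cause can be assigned to the lack of inhibition.

With the shared core unchanged, compound 3 is expected to behave like compound 2, and the step that the limit leaves unreadable from compound 2 to compound 3 is estimated to be none beyond the scatter. Compound 3 is expected at about 60000 nM, most likely again reported as a limit, in the range 25000 nM to 150000 nM.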

Compound 3, half-maximal inhibitory concentration: > 50000 nM
Compound 3: no number, only a limit; the forecaster's own chance of this, stated with the estimate: 85%; the middle value is on the limit's open side.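

Among these compounds, compound 2 and compound 3 both stop at the edge of what this assay can report, so no step between them can be read: the limit of > 50000 nM in this assay, at which 3 of the 3 values shown sit.

The compounds shown leave open how strongly each inhibits these cells, and whether 2,6-difluorophenyl in place of 2-chlorophenyl changes that at all.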